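A few compounds are considered here, and "the series" means these few. Any claim that something is new, unique, unknown or untested is made for them only; others in the source may bear on it.

Measured in a functional assay on RPMI-8226 cells (Homo sapiens) for inhibition, read by sulforhodamine B assay, with a stated time of 48 h; a higher number here means that more compound is tolerated, a lower number that less compound is tolerated:
- compound 1 `COc1ccc(-c2cc(/C=C/C(=O)c3ccc(N)cc3)[nH]n2)cc1`: 29400 nM
- compound 2 `COc1cc(-c2cc(/C=C/C(=O)c3ccc(N)cc3)[nH]n2)cc(OC)c1OC`: > 100000 nM (a limit)
- compound 3 `COc1cc(-c2cc(/C=C/C(=O)c3ccc(Cl)c(Cl)c3)[nH]n2)cc(OC)c1OC`: > 100000 nM (a limit)

Compound 2 has no number in this assay, and its > 100000 nM is a limit. Compound 3 gives > 100000 nM, which is also a limit. Together they form (the limit of > 100000 nM in this assay, at which 2 of the 3 values shown sit), and only compound 1 has a true number.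

Compound 4 `COc1cc(-c2cc(/C=C/C(=O)c3ccc(F)c(F)c3)[nH]n2)cc(OC)c1OC` differs from compound 2 by one change: 3,4-difluorophenyl in place of 4-aminophenyl on a carbonyl carbon. Among the measured compounds shown here, the one measured step that bears on this is a step that the two limits leave unreadable from compound 2 to compound 3, which also removes the 4-aminophenyl from the same carbonyl carbon. Its size cannot be read, so no size carries over from it. No step beyond the scatter is expected in this assay, in either direction, and a report as a limit alone is the likely outcome for compound 4.

The step expected is a number no higher from compound 2 to compound 4 (the limit leaves the size open). The estimated value for compound 4 is 100000 nM, with an expected range from 40000 nM to 200000 nM.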

Compound 4, concentration lethal to 50% of the cells: > 100000 nM
Compound 4 was reported as a limit (the forecaster's own chance of this, stated with the estimate: 75%); the middle value lies on the limit itself.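

Compound 4 gives > 100000 nM, which is a limit. With compound 2, compound 3 and compound 4 all reported as limits, no new step can be read among them: the limit of > 100000 nM in this assay, at which 3 of the 4 values shown sit.

The compounds shown leave open whether 4-aminophenyl, 3,4-dichlorophenyl or 3,4-difluorophenyl on the carbonyl carbon makes any difference to the value.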